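Alkyl branching on the double-bonded nitrogen

The source may hold more compounds than are shown below. What is called first, only, known or untested is meant among the compounds shown, and "the series" means these compounds.

Compound 1, `CC(C)CC/N=C(\NC#N)Nc1cccnc1`: 20 mg/kg
Compound 2, `CCCCC(CC)C/N=C(\NC#N)Nc1cccnc1`: > 50 mg/kg (a limit of the assay)
Compound 3, `CC(/N=C(/NC#N)Nc1cccnc1)C(C)(C)C`: 1 mg/kg

The three compounds share one core and differ only in the alkyl group on the double-bonded nitrogen. All were tested in a functional assay on the whole organism (blood, strain Wistar-Okamoto) with Rattus norvegicus as the target, with a stated time of 5 days; a higher number here means that more compound is needed for the effect, a lower number that less compound is needed. Among the two numbers reported, compound 1 has the higher one, with 20 mg/kg. Compound 3, which carries a branched group, gives 1 mg/kg, a far lower number; the gap is beyond the scatter. For compound 2 this assay gives only a limit, > 50 mg/kg, and no number.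

Compound 4, `CCC(C)(CC)/N=C(\NC#N)Nc1cccnc1`, has not yet been measured. It arises from compound 1 by the change (1-ethyl-1-methylpropyl in place of isopentyl on a double-bonded nitrogen). Since compound 3, with branching next to the nitrogen, gives 1 mg/kg while compound 1 gives 20 mg/kg, a step downward is expected for compound 4, estimated as a 6.7-fold lower number from compound 1 to compound 4 (0.82 log units; beyond the scatter). Compound 4 is therefore expected to need roughly 3 mg/kg, within a range from 0.7 mg/kg to 15 mg/kg.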

Compound 4, minimum effective dose: 0.5 mg/kg
Beside the measured number, compound 4's estimate is 6.0-fold (0.78 log units) above it; the whole stated range lies above it.
By their numbers in this assay, from the lowest: compounds 4 and 3 (each within the scatter of the next); then compound 1. At a limit, above all of these: compound 2.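

Going by these compounds alone, replacing isopentyl with 1-ethyl-1-methylpropyl on the double-bonded nitrogen gives a 40-fold lower number from compound 1 to compound 4 (1.60 log units; beyond the scatter) in this assay, the first step that can be read at this position. Compound 4 and compound 3 lie within the scatter of each other, so two different alkyl groups now reach the low end of the series, while the branched groups of compound 1 and compound 2 do not, which shows that branching alone does not give a low number. Nothing shown gives a cause for this step.

Within the data shown here, compound 2 has only a limit, > 50 mg/kg, and no step to it can be read. From the compounds shown here alone, whether a cyclohexyl ring, or a chain carrying a hydroxyl or an amine, would hold the number as low on this nitrogen remains open.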